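Trading 4-Fluorophenyl for 3-Methoxyphenyl

The source may hold more compounds than are shown below. What is called first, only, known or untested is meant among the compounds shown, and "the series" means these compounds.

Going by the values given here, in a functional assay on HeLa cells (Homo sapiens) for antiproliferative activity, read by MTT assay, with a stated time of 48 h (a lower number here means a stronger inhibitor, a higher number a weaker inhibitor), compound 2 (`Oc1ccc2ccccc2c1C(Nc1nc2ccc(Cl)cc2s1)c1cn(-c2ccccc2)nc1-c1ccc(F)cc1`) gives 30100 nM as the higher of the two numbers so far, which makes it the weaker inhibitor. Compound 1 (`COc1cccc(-c2nn(-c3ccccc3)cc2C(Nc2nc3ccc(OC)cc3s2)c2c(O)ccc3ccccc23)c1`) gives 10500 nM there, and that gap lies beyond the usual scatter. Next comes compound 3 (`COc1cccc(-c2nn(-c3ccccc3)cc2C(Nc2nc3ccc(Cl)cc3s2)c2c(O)ccc3ccccc23)c1`), in which 3-methoxyphenyl takes the place of 4-fluorophenyl on an aromatic carbon (3-methoxyphenyl in place of 4-fluorophenyl on an aromatic carbon). Among the compounds with values here, no measured pair shows this change alone. Compound 3 differs from compound 1 elsewhere too, yet compound 1 carries the same 3-methoxyphenyl and gives 10500 nM as a loose guide. A modest move toward a lower number in this assay is therefore expected, with a 2.2-fold lower number from compound 2 to compound 3 (0.33 log units; beyond the scatter) as the estimated step, only just beyond the scatter. The estimated value for compound 3 is 14000 nM with an expected range from 6000 nM to 32000 nM as the likely span.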

Compound 3, half-maximal inhibitory concentration: 30000 nM
Beside the measured number, compound 3's estimate is 2.1-fold (0.33 log units) below it, and the stated range covers the measured number.
By their numbers in this assay, from the lowest: compound 1; then compounds 3 and 2 (each within the scatter of the next).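

At this position on the five-membered ring, 3-methoxyphenyl and 4-fluorophenyl cannot be told apart in this assay: the result is a 1.0-fold lower number from compound 2 to compound 3 (0.00 log units; within the scatter) despite the added hydrogen-bond acceptor in 3-methoxyphenyl. Going by these compounds alone, the single change that does register lies elsewhere, as chloro in place of methoxy on an aromatic carbon gives a 2.9-fold higher number from compound 1 to compound 3 (0.46 log units; beyond the scatter) and so shows that this second site can shift the number when the aryl swap does not. Nothing measured here gives a reason for either result.

As far as these compounds go, whether a group of a different kind at the first position, such as an amine or a carboxylic acid on the phenyl ring, would stand apart from these two remains open. From the compounds shown here alone, it is also open whether the chloro and methoxy step would be the same with 4-fluorophenyl in place of 3-methoxyphenyl.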